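Esterifying the acid of compound 3: what to expect

A few compounds are considered here, and "the series" means these few. Any claim that something is new, unique, unknown or untested is made for them only; others in the source may bear on it.

Measured so far, in an assay on membranes from brain for antagonist activity at adenosine receptor A1 (Rattus norvegicus); on this read-out lower numbers stand for stronger inhibition and higher numbers for weaker inhibition:
compound 1 `CCCn1c(=O)c2nc(-c3ccc(C(N)=O)cc3)[nH]c2n(CCC)c1=O` gives 12 nM
compound 2 `CCCn1c(=O)c2nc(-c3ccc(C(=O)NCC(=O)OC)cc3)[nH]c2n(CCC)c1=O` gives 38 nM
compound 3 `CCCn1c(=O)c2nc(-c3ccc(OCC(=O)O)cc3O)[nH]c2n(CCC)c1=O` gives 37 nM

All three share the same core, carrying a substituted phenyl ring, and differ only in the groups on that ring. Among the three numbers, compound 3 stands second highest: its value and that of compound 2 lie within the scatter of each other, while compound 1 sits beyond the scatter with a lower number.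

The unmeasured compound 4 `CCCn1c(=O)c2nc(-c3ccc(OCC(=O)OCC)cc3O)[nH]c2n(CCC)c1=O` is derived from compound 3 by a single change: ethyl in place of hydrogen on an oxygen next to a carbonyl group, that is, carboxy to ethoxycarbonyl. Within the data shown here, no measured step capping the acid in this way exists here. Among the measured compounds shown here, the only step with one change, a 3.2-fold higher number from compound 1 to compound 2 (0.50 log units; beyond the scatter), attaches a (methoxycarbonyl)methyl group elsewhere and modestly weakened binding; it is a loose guide at best. A small shift in this assay is therefore expected, if any, for compound 4, with the step of a 1.2-fold higher number from compound 3 to compound 4 (0.09 log units; within the scatter) estimated. Compound 4 is expected at 45 nM, within 15 nM to 130 nM.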

Compound 4, antagonist equilibrium constant: 31 nM
Compound 4: middle estimate off by 1.5-fold (0.16 log units), on the high side, and the stated range covers the measured number.
By their numbers in this assay, from the lowest: compound 1; then compounds 4, 3 and 2 (each within the scatter of the next).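

In this assay, putting ethyl in place of hydrogen on the oxygen next to the carbonyl group, carboxy to ethoxycarbonyl, gives a 1.2-fold lower number from compound 3 to compound 4 (0.08 log units; within the scatter), so the acid and its ethyl ester cannot be told apart on this read-out. Among these compounds, this is the first look at this place on the molecule, and it shows that, for this pair, binding does not depend on keeping the free carboxy hydrogen: the ester, with its two added carbons, is accommodated as well as the acid. Nothing available here explains why the two compounds read alike.

Going by these compounds, it remains open whether a longer chain such as butyl on this oxygen, or an amide in place of the ester, would also read alike. Also open, on these data alone, is what the hydroxy on the phenyl ring contributes to this result.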